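Swapping Oxygen for Sulfur on a Shared Diamine Core

This account rests on a few compounds, and the source may have more. Where it says the series, first, only, none or still open, it means among the compounds named here.

Compound 1 `Nc1cc(N)c2nc(-c3ccccc3)c(Oc3ccc(Cl)c(Cl)c3)nc2c1`, measured in a functional assay on NCI-H522 cells (Homo sapiens) for inhibition, read by sulforhodamine B assay, with a stated time of 48 h (on this read-out lower numbers stand for higher toxicity in this test and higher numbers for lower toxicity in this test), gives < 100000 nM, a limit of the test rather than a number.
Compound 2 `CCOC(=O)[C@H](CCC(=O)O)NC(=O)c1ccc(CNc2nc3cc(N)cc(N)c3nc2-c2ccccc2)cc1` gives < 100000 nM in this assay, again only a limit.
Compound 3 `CCOC(=O)[C@H](CCC(=O)O)NC(=O)c1ccc(Oc2nc3cc(N)cc(N)c3nc2-c2ccccc2)cc1` gives < 100000 nM in this assay, also a limit.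

Compound 1 therefore stands at the limit of the test, and the same holds for the two other compounds measured alongside it: the limit of < 100000 nM in this assay, at which 3 of the 3 values shown sit. For the measured compounds named here, no two of these three compounds differ in only one place, so no measured step between them can be drawn, and nothing here tells how large a single change of this kind moves the read-out.

Compound 4 `Nc1cc(N)c2nc(-c3ccccc3)c(Sc3ccc(Cl)c(Cl)c3)nc2c1` has not yet been measured. It differs from compound 1 by (3,4-dichlorophenyl)sulfanyl in place of 3,4-dichlorophenoxy on an aromatic carbon. Since every measured value sits at the limit, the most likely outcome for compound 4 is expected to be a limit once more, and the step that the limit leaves unreadable from compound 1 to compound 4 is expected to stay within the usual scatter rather than point clearly in either direction. For compound 4 the estimate in this assay is 20000 nM, with a plausible range from 3000 nM to 100000 nM.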

Compound 4, concentration lethal to 50% of the cells: < 100000 nM
Compound 4: no number, only a limit; the forecaster's own chance of this, stated with the estimate: 70%; the middle value does not contradict the limit.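

For the compounds shown here, compound 1 and compound 4 both give only a limit of the test rather than a number, and no step between them can be read: the limit of < 100000 nM in this assay, at which 4 of the 4 values shown sit.
The compounds shown leave open what true values lie behind these limits in this assay and whether (3,4-dichlorophenyl)sulfanyl in place of 3,4-dichlorophenoxy changes the read-out at all.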